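A few compounds are considered here, and "the series" means these few. Any claim that something is new, unique, unknown or untested is made for them only; others in the source may bear on it.

Compound 1, `CC(=O)N1c2ccccc2CCC1C(=O)Nc1cc(C(F)(F)F)cc(C(F)(F)F)c1`, gives > 70000 nM in a functional assay on NUGC-3 cells (Homo sapiens) for cytotoxicity, read by sulforhodamine B assay, with a stated time of 72 h (on this read-out higher numbers stand for weaker inhibition of growth and lower numbers for stronger inhibition of growth), which is a limit of the assay rather than a number.
Compound 2, `CCCC(=O)N1c2ccccc2CCC1C(=O)Nc1cc(C(F)(F)F)cc(C(F)(F)F)c1`, gives 14400 nM in this assay.
Compound 3, `O=C(Nc1cc(C(F)(F)F)cc(C(F)(F)F)c1)C1CCc2ccccc2N1`, gives 8760 nM in this assay.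

Compound 3 has the lowest of the two numbers, but compound 2 sits within the usual scatter of it, so the two cannot be told apart; compound 1 contributes only a limit. Compound 4, `O=C(Nc1cc(C(F)(F)F)cc(C(F)(F)F)c1)C1CCc2ccccc2N1C(=O)c1ccccc1`, differs from compound 3 by benzoyl in place of hydrogen on a nitrogen on an aromatic ring in a ring.

For the measured compounds named here, two measured steps bear on this change, both running in the opposite direction, from an acyl group on that nitrogen to a hydrogen. Removing acetyl gave an at least 7.9-fold lower number from compound 1 to compound 3 (0.90 log units; beyond the scatter). Removing propylcarbonyl gave a 1.6-fold lower number from compound 2 to compound 3 (0.22 log units; within the scatter). Putting a benzoyl group in place of the hydrogen therefore reverses a move that once cost at least a modest amount and once cost nothing beyond the scatter; the larger acyl group sat closer to the free compound. A small rise in this assay is expected for compound 4, of a size near the edge of the scatter, and compound 4 is estimated at 12000 nM, between 4000 nM and 40000 nM. The expected step is a 1.4-fold higher number from compound 3 to compound 4 (0.14 log units; within the scatter).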

Compound 4, concentration for 50% growth inhibition: 1680 nM
Estimate against measurement, compound 4: 7.1-fold (0.85 log units) above, and the stated range ends above it.
By their numbers in this assay, from the lowest: compound 4; then compounds 3 and 2 (each within the scatter of the next). At a limit, above all of these: compound 1.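

Putting benzoyl on this nitrogen on an aromatic ring gives a 5.2-fold lower number from compound 3 to compound 4 (0.72 log units; beyond the scatter) in this assay, so an acyl group here can go with stronger inhibition of growth than the free hydrogen, which neither acetyl nor propylcarbonyl had shown. The earlier compounds shown here made acylation look neutral at best, but the group on the carbonyl carbon turns out to decide the outcome: phenyl in place of propyl gives an 8.6-fold lower number from compound 2 to compound 4 (0.93 log units; beyond the scatter), and phenyl in place of methyl gives an at least 41-fold lower number from compound 1 to compound 4 (1.61 log units; beyond the scatter). That last step starts from a limit of the assay for compound 1, not from a number: the limit of > 70000 nM in this assay, at which 1 of the 4 values shown sits.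

Phenyl is the only ring on this carbonyl carbon among the compounds shown, so they cannot tell whether the ring must be aromatic, as a cyclohexyl group in its place would test, or whether size alone would do, as a longer chain would test. They also leave open whether a methoxy group or a chlorine atom on the phenyl ring would lower the number further or raise it again.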